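This account rests on a few compounds, and the source may have more. Where it says the series, first, only, none or still open, it means among the compounds named here.

Measured in a functional assay on L1210 cells (Mus musculus) for antiproliferative activity, read by MTT assay, with a stated time of 72 h; on this read-out lower numbers stand for stronger inhibition and higher numbers for weaker inhibition:
- compound 1 `COc1cc(C2=NN(C(C)=O)C(c3cccc([N+](=O)[O-])c3)O2)cc(OC)c1OC`: 39000 nM
- compound 2 `COc1ccc(C2OC(c3cc(OC)c(OC)c(OC)c3)=NN2C(C)=O)cc1`: 57000 nM
- compound 3 `COc1cc(OC)cc(C2OC(c3cc(OC)c(OC)c(OC)c3)=NN2C(C)=O)c1`: 5900 nM

Compound 3 has the lowest number of the three, and its gaps to the other two lie beyond the scatter. Compound 4 `COc1cc(C2=NN(C(C)=O)C(c3ccccc3)O2)cc(OC)c1OC` differs from it in one place: phenyl in place of 3,5-dimethoxyphenyl on a saturated ring carbon. This puts phenyl in place of 3,5-dimethoxyphenyl on a saturated ring carbon.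

For the measured compounds named here, no compound with phenyl at this place has been measured, so the closest evidence is the other changes there. Replacing 3-nitrophenyl gave a 6.6-fold lower number from compound 1 to compound 3 (0.82 log units; beyond the scatter), and replacing 4-methoxyphenyl gave a 9.7-fold lower number from compound 2 to compound 3 (0.99 log units; beyond the scatter). Between those two groups, the data show a 1.5-fold higher number from compound 1 to compound 2 (0.16 log units; within the scatter). Compound 3 is therefore the only one of the three to stand apart, and losing its 3,5-dimethoxyphenyl group is expected to bring a modest rise in this assay, of about the same size as those two steps.

The expected step is a 5.6-fold higher number from compound 3 to compound 4 (0.75 log units; beyond the scatter). Compound 4 is estimated at 33000 nM, with an expected range of 11000 nM to 80000 nM.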

Compound 4, half-maximal inhibitory concentration: 6400 nM
Compound 4: middle estimate off by 5.2-fold (0.71 log units), on the high side, and the stated range ends above it.
By their numbers in this assay, from the lowest: compounds 3 and 4 (each within the scatter of the next); then compounds 1 and 2 (each within the scatter of the next).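

In this assay, the bare phenyl on the saturated ring carbon serves as well as 3,5-dimethoxyphenyl, with a 1.1-fold higher number from compound 3 to compound 4 (0.04 log units; within the scatter), so the two methoxy groups of compound 3 are not needed for its low number. For the compounds shown here, the earlier compounds could not show this, and the comparison now points the other way: there is an 8.9-fold lower number from compound 2 to compound 4 (0.95 log units; beyond the scatter) on losing the single methoxy group, and a 6.1-fold lower number from compound 1 to compound 4 (0.78 log units; beyond the scatter) on losing the nitro group. A single methoxy or nitro group on this phenyl therefore goes with the higher numbers, yet compound 3 goes against any rule that groups on this ring raise the number.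

From the compounds shown here alone, how an amine or a carboxylic acid on this phenyl would behave remains open. Nothing shown explains why these groups differ in this way.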